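The compounds below may be only part of what the source reports. "The series", "measured", "known", "first", "only" and "open" are said of these compounds alone.

Compound 1 `CC(C)c1ccc(CNCCCOc2cccc3ccc(N)nc23)cc1` – in an assay on cells with melanin-concentrating hormone receptor 1 (Homo sapiens) as the target, read by radioligand binding (a higher number here means a weaker inhibitor, a lower number a stronger inhibitor), compound 1 gives 10 nM
Compound 2 `COc1cccc(C(=O)NCCCOc2cccc3ccc(N)nc23)c1` – in this assay compound 2 gives 2 nM

Of these two numbers, compound 2 stands at the lower one, and the gap to compound 1 lies beyond the usual scatter. Compound 3 `Nc1ccc2cccc(OCCCNC(=O)c3cccc(OC(F)(F)F)c3)c2n1` differs from compound 2 only in one place: trifluoromethyl in place of methyl on an oxygen on an aromatic ring. Within the data shown here, no measured pair in this set shows this kind of change, so its effect is not known from the data; a small shift, at most a modest weakening, is expected, as the step of a 2.0-fold higher number from compound 2 to compound 3 (0.30 log units; within the scatter) expresses. For compound 3 in this assay the estimate is 4 nM, with a range from 1 nM to 15 nM.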

Compound 3, half-maximal inhibitory concentration: 6 nM
For compound 3 the middle estimate is 1.5-fold (0.18 log units) below the measured one; low and high end bracket the measured number.
By their numbers in this assay, from the lowest: compound 2; then compounds 3 and 1 (each within the scatter of the next).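

Trifluoromethyl in place of methyl on an oxygen on an aromatic ring gives a 3.0-fold higher number from compound 2 to compound 3 (0.48 log units; beyond the scatter) in this assay. Among these compounds, this is the first reading of this change, and it shows that the place tolerates the swap from methoxy to trifluoromethoxy with a modest weakening, though one that lies beyond the scatter. No measurement shown here accounts for the step.

On these data alone, it remains open whether ethyl in place of methyl on that oxygen would raise the number likewise. As far as these compounds go, the effect of a nitrile replacing the whole methoxy also remains open.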